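The source may hold more compounds than are shown below. What is called first, only, known or untested is meant among the compounds shown, and "the series" means these compounds.

Measured compounds:
compound 1 `Nc1scc(CN2CCN(c3ccc([N+](=O)[O-])cc3)CC2)c1C(=O)c1ccc(Cl)cc1` — 2%
compound 2 `Nc1scc(CN2CCN(C3CCCC3)CC2)c1C(=O)c1ccc(Cl)cc1` — 3%

In an assay on CHO cells for displacement of a labelled ligand from adenosine receptor A3 (Homo sapiens), read by scintillation counting, with a stated time of 120 min, tested at 10 uM (on this read-out higher numbers stand for more inhibition at the one concentration tested (going by the name of the read-out) and lower numbers for less inhibition), compound 1 gives 2%. In this assay compound 2 gives 3%. Going by the values given here, compound 2 stands at the top of these two numbers, but its only neighbour is compound 1, and the step of a number 1 percentage points higher from compound 1 to compound 2 (within the scatter) lies within the scatter, so the two compounds cannot be told apart on this read-out; both sit near the floor of the measurement.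

Compound 3 `Nc1scc(CN2CCN(c3cc(F)cc(F)c3)CC2)c1C(=O)c1ccc(Cl)cc1` is the next compound in line. It differs from compound 2 by 3,5-difluorophenyl in place of cyclopentyl on an amine nitrogen in a ring. Among the compounds with values here, the one measured step that bears on this position is a number 1 percentage points higher from compound 1 to compound 2 (within the scatter), in which an aromatic group on the same ring nitrogen was exchanged for cyclopentyl with no change beyond the scatter. The change to compound 3 exchanges that cyclopentyl for another aromatic group in the same place, so no movement beyond the scatter is expected in this assay, in either direction. For compound 3 the expected step is no change at the digits printed from compound 2 to compound 3 (within the scatter). Compound 3 is therefore estimated at 3%, within a range from -5% to 12%.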

Compound 3, a percentage reported as inhibition, at one concentration (the size of the read-out at that concentration, not a potency): 2%
Beside the measured number, compound 3's estimate is 1 percentage points above it; the measured number falls inside the stated range.
By their numbers in this assay, from the lowest: compounds 1, 3 and 2 (each within the scatter of the next).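

In this assay, the exchange of cyclopentyl for 3,5-difluorophenyl gives a number 1 percentage points lower from compound 2 to compound 3 (within the scatter), and the exchange of 4-nitrophenyl for 3,5-difluorophenyl gives no change at the digits printed from compound 1 to compound 3 (within the scatter). The new result adds a third group on this amine nitrogen in a ring, and the three compounds cannot be told apart: an aromatic ring carrying two fluorine atoms reads like both the five-membered non-aromatic carbon ring and the aromatic ring carrying a nitro group, so neither the kind of ring nor the choice between these two aromatic groups separates the compounds here, and all three remain near the floor of the measurement. Nothing at hand explains why the read-out stays so flat across these groups.

On these data alone, whether any other group on this ring nitrogen could lift the number clear of the floor remains open, for example a chain ending in an amine, a carboxylic acid or a longer alkyl chain. The rest of the core is the same in all three compounds, so they also leave open what a change elsewhere in the structure would do in this assay.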